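Aryl exchange on the shared core: working notes

The source may report more compounds than this note shows. Statements on the series, on what has been measured and on what is new or still open speak of the compounds shown alone.

Measured so far in a functional assay on HeLa cells (Homo sapiens) for inhibition, read by CCK-8 assay, with a stated time of 48 h (on this read-out higher numbers stand for weaker inhibition and lower numbers for stronger inhibition), for two compounds
Compound 1 `COc1cc(-c2ccnc3cc(-c4ccc(C)c(C)c4)nn23)cc(OC)c1OC` gives 241 nM in this read-out
Compound 2 `COc1cc(-c2ccnc3cc(-c4ccc5ccn(C)c5c4)nn23)cc(OC)c1OC` gives 187 nM in this read-out

Compound 2 at 187 nM and compound 1 at 241 nM sit within the scatter of each other, so no order can be read between them. Within the data shown here, the only measured step is a 1.3-fold lower number from compound 1 to compound 2 (0.11 log units; within the scatter) and it stays within the scatter. That step puts 1-methyl-1H-indol-6-yl in place of 3,4-dimethylphenyl on an aromatic carbon.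

Compound 3 `COc1ccc(-c2cc3nccc(-c4cc(OC)c(OC)c(OC)c4)n3n2)cc1` is the next case. It carries 4-methoxyphenyl in place of 1-methyl-1H-indol-6-yl on an aromatic carbon of a five-membered aromatic ring with 2 nitrogen, part of a fused or bridged system of two rings (4-methoxyphenyl in place of 1-methyl-1H-indol-6-yl on an aromatic carbon). Resting on a 1.3-fold lower number from compound 1 to compound 2 (0.11 log units; within the scatter) alone, no step beyond the scatter is expected in this assay for this exchange, although a single pair is thin support. The expected move is a 1.3-fold higher number from compound 2 to compound 3 (0.13 log units; within the scatter) on this estimate. For compound 3 the estimated value is 250 nM with an expected range from 90 nM to 700 nM as working bounds.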

Compound 3, half-maximal inhibitory concentration: 373 nM
For compound 3 the middle estimate is 1.5-fold (0.17 log units) below the measured one; low and high end bracket the measured number.
By their numbers in this assay, from the lowest: compounds 2, 1 and 3 (each within the scatter of the next).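

Compound 3 adds a third aryl group on this aromatic carbon of the five-membered aromatic ring, and in this assay putting 4-methoxyphenyl in place of 1-methyl-1H-indol-6-yl gives a 2.0-fold higher number from compound 2 to compound 3 (0.30 log units; within the scatter) and putting it in place of 3,4-dimethylphenyl gives a 1.5-fold higher number from compound 1 to compound 3 (0.19 log units; within the scatter) in the same read-out. Both steps stay within the scatter, so the earlier single pair now becomes three pairs with no readable order among them: a two-ring aryl group with a ring nitrogen, a dimethyl-substituted phenyl and a methoxy-substituted phenyl all remain indistinguishable at this position, a statement that holds for these three compounds only. No supporting data accompany these numbers that could explain them.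

Still open, on these data alone, is whether this position stays as undemanding for groups other than aryl rings, such as an amine, a carboxylic acid or a longer alkyl chain. Every compound shown also carries the same aryl group elsewhere on the shared core, so what an exchange at that second place would do to the number remains unknown.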